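The source may hold more compounds than are shown below. What is called first, only, known or untested is meant among the compounds shown, and "the series" means these compounds.

Measured in an ADME assay on HEK-293T cells (Homo sapiens) for cytotoxicity, read by MTT assay, with a stated time of 24 h; a lower number here means that less compound is tolerated, a higher number that more compound is tolerated:
- compound 1, `Cc1ccc(-c2nn(-c3ccccc3)cc2-c2nc3ccccc3n2C(=O)c2cncc(C)c2)cc1`: 155000 nM
- compound 2, `O=C(c1cccnc1)n1c(-c2cn(-c3ccccc3)nc2-c2ccc(F)cc2)nc2ccccc21`: 216000 nM
- compound 3, `Cc1ccc(-c2nn(-c3ccccc3)cc2-c2nc3ccccc3n2C(=O)c2ccc(Cl)cc2)cc1`: 216000 nM

Compound 3 stands level with compound 2 at the digits shown, the two together the highest of the three numbers; compound 1 lies a little lower, the step of a 1.4-fold higher number from compound 1 to compound 3 (0.14 log units; within the scatter) being within the scatter. The three numbers are therefore all of one size in this assay.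

Compound 4, `Cc1ccc(-c2nn(-c3ccccc3)cc2-c2nc3ccccc3n2C(=O)c2cccnc2)cc1`, is not yet measured. It differs from compound 3 by pyridin-3-yl in place of 4-chlorophenyl on a carbonyl carbon. Going by the values given here, the one step that bears on this is a 1.4-fold higher number from compound 1 to compound 3 (0.14 log units; within the scatter), which exchanges the same place and stays within the scatter; compound 2, carrying the same pyridin-3-yl carbonyl on a different core, gives a number level with compound 3. Nothing here points to a change beyond the scatter, so the step of a 1.1-fold lower number from compound 3 to compound 4 (0.06 log units; within the scatter) is expected to be small. Compound 4 is estimated at 190000 nM, with a range of 110000 nM to 320000 nM.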

Compound 4, half-maximal cytotoxic concentration: 189000 nM
Estimate against measurement, compound 4: 1.0-fold (0.00 log units) above, within the range that was stated.
By their numbers in this assay, from the lowest: compounds 1, 4, 2 and 3 (each within the scatter of the next).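

In this assay compound 4 links all three earlier compounds by single changes, and pyridin-3-yl in place of 4-chlorophenyl on the carbonyl carbon gives a 1.1-fold lower number from compound 3 to compound 4 (0.06 log units; within the scatter) with no step beyond the scatter. The two other exchanges read alike: methyl in place of fluoro on an aromatic carbon gives a 1.1-fold lower number from compound 2 to compound 4 (0.06 log units; within the scatter) and hydrogen in place of methyl on an aromatic carbon gives a 1.2-fold higher number from compound 1 to compound 4 (0.09 log units; within the scatter), so each of the three single changes leaves the number within the scatter. No measurement at hand offers a reason for this flat picture.

From the compounds shown here alone, whether an amine or a carboxylic acid on the ring held by the carbonyl would give a step beyond the scatter remains open. So does the outcome of replacing that ring with a longer alkyl chain.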